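Tail flick series: side-chain variation on a shared core

This account rests on a few compounds, and the source may have more. Where it says the series, first, only, none or still open, it means among the compounds named here.

Measured compounds:
compound 1, `N=C(N)NCCC[C@H](NC(=O)CN(c1nc(Cl)nc2[nH]cnc12)C1CC1)C(=O)O` — 45.4%
compound 2, `C[C@@H](O)[C@H](NC(=O)CN(c1nc(Cl)nc2[nH]cnc12)C1CC1)C(=O)O` — 18.6%
compound 3, `NCCCC[C@H](NC(=O)CN(c1nc(Cl)nc2[nH]cnc12)C1CC1)C(=O)O` — 31.2%

In a functional assay on the whole organism (Tail, strain ICR) with Mus musculus as the target, in the tail flick test, with a stated time of 30 min, at a dose of 25 umol/kg by the oral route (a higher number here means a stronger effect of the compound at the dose given, a lower number a weaker effect), compound 3 stands second highest of the three. Its nearest neighbour is compound 2, a number 12.6 percentage points higher from compound 2 to compound 3 (beyond the scatter); the furthest is compound 1, a number 14.2 percentage points lower from compound 1 to compound 3 (beyond the scatter).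

The unmeasured compound 4, `CC(C)[C@H](NC(=O)CN(c1nc(Cl)nc2[nH]cnc12)C1CC1)C(=O)O`, differs from compound 3 by isopropyl in place of 4-aminobutyl on a saturated chain carbon bound to an amide-type nitrogen and a carbonyl carbon.

Among the compounds with values here, two measured steps bear on this change. Going from compound 2 to compound 3, a number 12.6 percentage points higher from compound 2 to compound 3 (beyond the scatter), a larger side chain with an amine enters in place of a hydroxyethyl. Going from compound 1 to compound 3, a number 14.2 percentage points lower from compound 1 to compound 3 (beyond the scatter), a guanidine is cut back to an amine and the read-out falls. Going from compound 1 to compound 2, a number 26.8 percentage points lower from compound 1 to compound 2 (beyond the scatter), the read-out falls further still. Across all three, trimming the side chain to fewer nitrogen atoms has gone with a lower read-out in this assay; no measured compound runs against this. Compound 4 goes one step further in that direction, to a side chain with no heteroatom at all.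

Compound 4 is therefore expected to give a lower read-out than compound 3, a number 16.2 percentage points lower from compound 3 to compound 4 (beyond the scatter), a modest drop beyond the scatter. The estimate for compound 4 in this assay is 15%, with a range from 4% to 30%.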

Compound 4, a percentage reported as activity, at one dose (the size of the read-out at that dose, not a potency): 31.2%
Beside the measured number, compound 4's estimate is 16.2 percentage points below it; the measured number lies above the stated range.
By their numbers in this assay, from the lowest: compound 2; then compounds 3 and 4 (each within the scatter of the next); then compound 1.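

In this assay, isopropyl in place of 4-aminobutyl on a saturated chain carbon bound to an amide-type nitrogen and a carbonyl carbon gives no change at the digits printed from compound 3 to compound 4 (within the scatter) and so removes the nitrogen of the side chain with no measurable cost. This breaks the earlier link between fewer side-chain nitrogens and a lower read-out: compound 4 goes against it, and nitrogen count alone no longer orders the four compounds. The two side chains without nitrogen also stand apart, with a number 12.6 percentage points higher from compound 2 to compound 4 (beyond the scatter) for isopropyl in place of 1-hydroxyethyl, while the guanidine-bearing side chain keeps its separation, with a number 14.2 percentage points lower from compound 1 to compound 4 (beyond the scatter) for the smaller all-carbon group.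

Still open, on these data alone, is how a longer unbranched alkyl chain or a benzyl group on this same carbon would read in this assay, and so whether all-carbon side chains in general match compound 4 or isopropyl is a special case. Nothing available on these compounds accounts for any of these steps.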